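Allyloxy on the Fused Ring of the Hydrazide Series

A few compounds are considered here, and "the series" means these few. Any claim that something is new, unique, unknown or untested is made for them only; others in the source may bear on it.

Compound 1 `CCCNNC(=O)c1ccc(CNC(=O)c2cc3ccccc3o2)cc1` is a propylhydrazide carrying a benzofuran-type amide arm. In an assay on isolated protein for inhibition of protein deacetylase HDAC6 (Homo sapiens), read by fluorescence, with a stated time of 2 h (a lower number here means a stronger inhibitor, a higher number a weaker inhibitor), compound 1 returns only a limit, > 10000 nM, not a number. Compound 2 `CCCNNC(=O)c1ccc(CNC(=O)c2nc3ccccc3[nH]2)cc1` replaces the ring oxygen with a ring nitrogen bearing a hydrogen; in this assay compound 2 also sits at the limit, > 10000 nM. Compound 3 `CCCNNC(=O)c1ccc(CNC(=O)c2nc3ccccc3s2)cc1` carries sulfur in that ring; in this assay compound 3 gives the limit > 10000 nM as well. All three values shown are limits, so compound 1 cannot be placed relative to the others beyond saying that every value sits where the limit of > 10000 nM in this assay, at which 3 of the 3 values shown sit, lies.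

Compound 4 `C=CCOc1ccc2oc(C(=O)NCc3ccc(C(=O)NNCCC)cc3)cc2c1` differs from compound 1 by allyloxy in place of hydrogen on an aromatic carbon of the fused system. For the measured compounds named here, no measured step exists between compounds that differ in one place, so the data give no direction for this addition. The step from compound 1 to compound 4 is expected to be a step that the limit leaves unreadable from compound 1 to compound 4, essentially none beyond the scatter. Compound 4 is therefore estimated at 15000 nM, with a range from 5000 nM to 50000 nM, most likely again reported only as a limit.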

Compound 4, half-maximal inhibitory concentration: > 10000 nM
Compound 4 ended at the assay's limit; the forecaster's own chance of this, stated with the estimate: 80%; the middle value lies beyond the limit too.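

In this assay compound 4 gives > 10000 nM, a limit and not a number. No step from compound 1 to compound 4 can be read, because both values are limits: the limit of > 10000 nM in this assay, at which 4 of the 4 values shown sit.

The compounds shown leave open whether allyloxy in place of hydrogen on an aromatic carbon alters inhibition at all.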